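Ring swap on the ether of compound 2

The compounds below may be only part of what the source reports. "The series", "measured", "known", "first", "only" and "open" are said of these compounds alone.

Compound 1 `CC(C)[C@H](NC(=O)COc1cccc2ccccc12)C(=O)N[C@@H](CC(=O)O)C(=O)COc1ccncn1` and compound 2 `CC(C)[C@H](NC(=O)COc1cccc2ccccc12)C(=O)N[C@@H](CC(=O)O)C(=O)COc1cc2ccccc2cn1` share one core and differ only at the ether on the saturated carbon. In a functional assay on Jurkat cells (Homo sapiens) for inhibition (on this read-out lower numbers stand for stronger inhibition and higher numbers for weaker inhibition), compound 1 reaches only the limit > 200000 nM. In this assay compound 2 likewise reaches only the limit > 200000 nM. The step that the two limits leave unreadable from compound 1 to compound 2 is therefore unreadable, as the limit of > 200000 nM in this assay, at which 2 of the 2 values shown sit, holds both values. Compound 3 `CC(C)[C@H](NC(=O)COc1cccc2ccccc12)C(=O)N[C@@H](CC(=O)O)C(=O)COc1[nH]cnc2nncc1-2` carries a group of 9 heavy atoms (5 carbon, 4 nitrogen; one five-membered aromatic ring with 2 hetero atoms, one six-membered aromatic ring with 2 hetero atoms) in place of a group of 10 heavy atoms (9 carbon, 1 nitrogen; one six-membered aromatic ring of carbon only, one six-membered aromatic ring with 1 hetero atom), on an oxygen on a saturated carbon. Within the data shown here, no measured step reads out, so the expected step that the limit leaves unreadable from compound 2 to compound 3 is taken as nothing beyond the scatter. Compound 3 is expected at 250000 nM, within 60000 nM to 1000000 nM, most probably again reported as a limit.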

Compound 3, half-maximal inhibitory concentration: 161000 nM
Beside the measured number, compound 3's estimate is 1.6-fold (0.19 log units) above it, within the range that was stated.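

Among these compounds, compound 3 is the first compound here to give a number rather than a limit in this assay, so a change on an oxygen on a saturated carbon can now register on this read-out. The new group gives an at least 1.2-fold lower number from compound 2 to compound 3 (0.09 log units; that floor lies within the scatter), and against the smaller ring it gives an at least 1.2-fold lower number from compound 1 to compound 3 (0.09 log units; that floor lies within the scatter). The remaining step cannot be read, and the limit still holds most of the values: the limit of > 200000 nM in this assay, at which 2 of the 3 values shown sit.

Going by these compounds, whether a simple amine or a carboxylic acid at this place would move the number clearly away from the limit stays open. Also open, on these data alone, is whether a change elsewhere on the shared core would do more than one at this place.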